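The source may report more compounds than this note shows. Statements on the series, on what has been measured and on what is new or still open speak of the compounds shown alone.

Measured compounds:
compound 1 `Oc1cccc(-c2cc(-c3ccsc3)nc(-c3cccc(Cl)c3)c2)c1`, 3330 nM in a functional assay on DU-145 cells (Homo sapiens) for cytotoxicity, read by CCK-8 assay and cell counting, with a stated time of 2 days; a higher number here means a weaker inhibitor, a lower number a stronger inhibitor
compound 2 `Oc1cccc(-c2cc(-c3ccccc3)nc(-c3ccccc3Cl)c2)c1`, 1480 nM

Of the two compounds measured in this assay, compound 2 stands at the lower number with 1480 nM; its nearest neighbour, compound 1, gives a higher value, and that gap lies beyond the usual scatter. Compound 3 `Oc1cccc(-c2cc(-c3ccccc3)nc(-c3cccc(Cl)c3)c2)c1` has not yet been measured in this assay. It differs from compound 2 in a single place: 3-chlorophenyl in place of 2-chlorophenyl on an aromatic carbon. For the measured compounds named here, no two measured compounds differ by this change alone, so there is no measured step to anchor the expectation. A small step in either direction, not clearly beyond the scatter, is expected for compound 3, with slightly more weight on a weaker result. Compound 3 is therefore estimated at 2000 nM, within a range from 800 nM to 5000 nM. The expected step is a 1.4-fold higher number from compound 2 to compound 3 (0.13 log units; within the scatter).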

Compound 3, half-maximal inhibitory concentration: 2750 nM
Estimate against measurement, compound 3: 1.4-fold (0.14 log units) below; the range from low to high includes it.
By their numbers in this assay, from the lowest: compounds 2, 3 and 1 (each within the scatter of the next, the first and the last beyond it).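

In this assay, 3-chlorophenyl in place of 2-chlorophenyl, on the aromatic carbon next to the ring nitrogen, gives a 1.9-fold higher number from compound 2 to compound 3 (0.27 log units; within the scatter), so the two chlorophenyl groups at this position cannot be told apart here. For the compounds shown here, compound 3 also provides the first single-place comparison with a sulfur-containing ring: phenyl in place of thiophen-3-yl gives a 1.2-fold lower number from compound 1 to compound 3 (0.08 log units; within the scatter), so this exchange likewise stays inside the noise of the assay. No independent data bear on what lies behind either step. The compounds shown leave open whether a carboxylic acid or an amine in place of the chlorine would give a step beyond the scatter. They also leave open what a methoxy group in place of the hydroxyl on the 3-hydroxyphenyl group would do.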